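The source may hold more compounds than are shown below. What is called first, only, known or untested is meant among the compounds shown, and "the series" means these compounds.

Compounds measured so far:
- Compound 1, `Cn1c(=O)c2c(nc(SCCc3ccc(Br)cc3)n2C)n(C)c1=O`: 108000 nM
- Compound 2, `Cn1c(=O)c2c(nc(SCCc3ccc(F)cc3)n2C)n(C)c1=O`: 14700 nM
- Compound 3, `Cn1c(=O)c2c(nc(SCc3cccc(Cl)c3)n2C)n(C)c1=O`: 6430 nM

All three share the same core and differ only in the sulfur-linked side chain. In an assay on microsomes for inhibition of Amine oxidase [flavin-containing] A (Homo sapiens), read by fluorescence and spectrophotometry, with a stated time of 20 min (a higher number here means a weaker inhibitor, a lower number a stronger inhibitor), compound 3 gives the lowest number of the three, and both steps toward it are beyond the scatter: a 17-fold lower number from compound 1 to compound 3 (1.23 log units; beyond the scatter) and a 2.3-fold lower number from compound 2 to compound 3 (0.36 log units; beyond the scatter).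

Compound 4 is `Cn1c(=O)c2c(nc(SCc3cccc(Br)c3)n2C)n(C)c1=O`. It differs from compound 3 by one change: bromo in place of chloro on an aromatic carbon. Going by the values given here, only one measured step swaps one halogen for another on the ring: a 7.3-fold lower number from compound 1 to compound 2 (0.87 log units; beyond the scatter), where a smaller halogen in place of bromo lowered the number. Read in the other direction, moving from a smaller halogen to bromo raised it. Chloro sits between fluoro and bromo in size, so the swap in compound 4 is expected to raise the number, but by a smaller amount than that step, likely close to the edge of the scatter. The estimated step is a 1.9-fold higher number from compound 3 to compound 4 (0.27 log units; within the scatter). For compound 4 the expected value in this assay is 12000 nM, with a range from 4000 nM to 40000 nM.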

Compound 4, half-maximal inhibitory concentration: 37900 nM
Estimate against measurement, compound 4: 3.2-fold (0.50 log units) below, within the range that was stated.
By their numbers in this assay, from the lowest: compound 3; then compound 2; then compound 4; then compound 1.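

Swapping one halogen atom on this ring matters on its own in this assay: a 5.9-fold higher number from compound 3 to compound 4 (0.77 log units; beyond the scatter) is a step well beyond the scatter, so the low number of compound 3 depends on chloro specifically and not just on having a halogen there. With bromo at this place the side chain no longer has the lowest number, since a 2.6-fold higher number from compound 2 to compound 4 (0.41 log units; beyond the scatter) puts it on the weaker side of the fluoro compound, although a 2.8-fold lower number from compound 1 to compound 4 (0.45 log units; beyond the scatter) keeps it on the stronger side of the other bromo compound. Nothing available here explains why bromo and chloro differ so much at this place.

Still open, from the compounds shown here alone, is how 3-fluorophenyl or 3-methylphenyl would compare with 3-chlorophenyl on the same side chain. Also open, going by these compounds, is how much of the remaining gaps comes from chain length and how much from where the halogen sits on the ring, since compound 1 and compound 2 differ from compound 4 in both.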